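Ester in place of methyl on the benzylic carbon

This account rests on a few compounds, and the source may have more. Where it says the series, first, only, none or still open, it means among the compounds named here.

Among the compounds with values here, compound 2 `C[C@H](NC(=O)c1[nH]cnc1C(=O)Nc1ccc(Cl)c(Cl)c1)c1ccccc1` gives 5900 nM in a functional assay on HL-60 cells (Homo sapiens), with a stated time of 4 days (a higher number here means a weaker inhibitor, a lower number a stronger inhibitor), the lowest of the three numbers so far. Compound 1 `O=C(Nc1ccc(Cl)c(Cl)c1)c1nc[nH]c1C(=O)NCc1ccc(Cl)cc1` gives 8800 nM in this assay, and the two values are within the scatter of each other, the step being a 1.5-fold lower number from compound 1 to compound 2 (0.17 log units; within the scatter). Compound 3 `CC(C)(C)OC(=O)CNC(=O)c1[nH]cnc1C(=O)Nc1ccc(Cl)c(Cl)c1` gives 25400 nM in this assay.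

Compound 4 `COC(=O)[C@H](NC(=O)c1[nH]cnc1C(=O)Nc1ccc(Cl)c(Cl)c1)c1ccccc1` has not been measured. Relative to compound 2 the change is methoxycarbonyl in place of methyl on a saturated chain carbon bound to an amide-type nitrogen and an aromatic carbon; the phenyl on that carbon is kept.

Within the data shown here, two measured steps bear on it, each bringing an ester onto the amide-side chain: a 2.9-fold higher number from compound 1 to compound 3 (0.46 log units; beyond the scatter) and a 4.3-fold higher number from compound 2 to compound 3 (0.63 log units; beyond the scatter). Both went toward weaker inhibition, although in both the aromatic group on that chain was lost at the same time, which is not the case for compound 4. A smaller shift in the same direction is therefore expected here, and a step within the scatter cannot be excluded.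

For compound 4 the expected step is a 1.6-fold higher number from compound 2 to compound 4 (0.21 log units; within the scatter), giving an estimate of 9500 nM in this assay, with a range from 4000 nM to 25000 nM.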

Compound 4, half-maximal inhibitory concentration: 10800 nM
For compound 4 the middle estimate is 1.1-fold (0.06 log units) below the measured one; low and high end bracket the measured number.
By their numbers in this assay, from the lowest: compounds 2, 1 and 4 (each within the scatter of the next); then compound 3.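

With the phenyl kept, methoxycarbonyl in place of methyl on the saturated chain carbon bound to an amide-type nitrogen and an aromatic carbon gives a 1.8-fold higher number from compound 2 to compound 4 (0.26 log units; within the scatter) in this assay, so compound 2 and compound 4 cannot be told apart in this assay. The ester is therefore accepted at this position when the aromatic group stays, unlike the step beyond the scatter to compound 3, which carries a different ester and has no aromatic group on that chain: a 4.3-fold higher number from compound 2 to compound 3 (0.63 log units; beyond the scatter). No measurement shown gives a reason for this result.

Going by these compounds, how a carboxylic acid or a primary amide in place of methoxycarbonyl on that carbon would read remains open. The compounds shown also leave open whether an ester with a longer chain would stay within the scatter of compound 2.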